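Primary sulfonamide against a methylpiperazinyl sulfonamide

The compounds below may be only part of what the source reports. "The series", "measured", "known", "first", "only" and "open" are said of these compounds alone.

The study examines a pair of compounds sharing one core. Compound 1 `CCNS(=O)(=O)Cc1noc2ccccc12` carries an ethyl group on the sulfonamide nitrogen; in a functional assay on the whole organism (strain STD-dd) with Mus musculus as the target, in the maximal electroshock model, with a stated time of 2 h (on this read-out lower numbers stand for an effect already at smaller amounts and higher numbers for an effect only at larger amounts of compound), compound 1 gives 39 mg/kg. Compound 2 `NS(=O)(=O)Cc1noc2ccc(F)cc12` adds a fluorine to the ring and leaves the sulfonamide nitrogen bare; in this assay compound 2 gives 15 mg/kg, the lower of the two numbers shown, with compound 1 standing well apart from it.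

Compound 3 `CN1CCN(S(=O)(=O)Cc2noc3ccc(F)cc23)CC1` differs from compound 2 at one place: 4-methylpiperazin-1-yl in place of amino on a sulfonyl sulfur. Going by the values given here, no measured pair shows this change by itself, so the size of its effect is unknown. The writer expects compound 3 to need somewhat more material than compound 2, a step of a 1.9-fold higher number from compound 2 to compound 3 (0.27 log units; within the scatter) that may stay near the scatter. Compound 3 is therefore estimated at 28 mg/kg, within a range from 10 mg/kg to 75 mg/kg.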

Compound 3, dose for half-maximal effect: 100 mg/kg
Compound 3: the middle estimate sits 3.6-fold (0.55 log units) below what was measured; measured number outside the range, above it.
By their numbers in this assay, from the lowest: compound 2; then compound 1; then compound 3.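

Replacing amino on the sulfonyl sulfur with 4-methylpiperazin-1-yl gives, in this assay, a 6.7-fold higher number from compound 2 to compound 3 (0.82 log units; beyond the scatter), so at this position the larger group comes with a clear need for more compound. Going by these compounds alone, this is the first change at this position that can be read by itself, since compound 1 and compound 2 differ in both the ring fluorine and the group on the sulfonamide nitrogen. Nothing measured here accounts for the size of this step.

The effects of the ethyl group and the fluorine therefore remain unseparated. Going by these compounds, it also stays open whether a methyl or ethyl group on the nitrogen of the fluorinated core, or a morpholine ring in place of the 4-methylpiperazin-1-yl group, would give a number closer to that of compound 2.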